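Shrinking the Thioether Ring from Cyclohexyl to Cyclopropyl

The source may hold more compounds than are shown below. What is called first, only, known or untested is meant among the compounds shown, and "the series" means these compounds.

Measured compounds:
compound 1 `Cc1cc(Nc2cc(-c3ccccc3)[nH]n2)n2nc(SCC3CCCCC3)nc2n1` gives > 50000 nM in this assay.
compound 2 `Cc1cc(Nc2cc(-c3ccc(F)cc3)[nH]n2)n2nc(SCc3ccc(Br)cc3)nc2n1` gives 4570 nM.
compound 3 `COc1ccc(Cn2ccc(Nc3cc(C)nc4nc(SCc5ccc(Br)cc5)nn34)n2)cc1` gives 14600 nM.

The three compounds share one core and were tested in a functional assay on MCF7 cells (Homo sapiens) for inhibition, read by MTT assay, with a stated time of 72 h; on this read-out lower numbers stand for stronger inhibition and higher numbers for weaker inhibition. Among the measured compounds shown here, compound 1 stands at a limit of the assay: its reading is a limit and not a number, and it sits at the limit of > 50000 nM in this assay, at which 1 of the 3 values shown sits, which no other compound here reaches. For the measured compounds named here, compound 2 and compound 3 each give a number, and the two numbers differ from one another by more than the usual scatter, but neither differs from compound 1 in a single place, so only their two values can be compared and no step between them is drawn.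

Compound 4 `Cc1cc(Nc2cc(-c3ccccc3)[nH]n2)n2nc(SCC3CC3)nc2n1` is the untested partner of compound 1. The change is cyclopropyl in place of cyclohexyl on a saturated chain carbon bound to a sulfur; the rest of the molecule is untouched. Nothing measured here shows how a smaller ring on that sulfanyl chain changes activity, so the expectation rests on compound 1 alone. Since compound 1 stands at a limit, compound 4 is expected to remain in the same region, with the step of a number no higher from compound 1 to compound 4 (the limit leaves the size open) expected to be none beyond the scatter. The estimate for compound 4 is 50000 nM, between 20000 nM and 120000 nM, with a real chance that this assay again reports only a limit.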

Compound 4, half-maximal inhibitory concentration: > 50000 nM
Compound 4 gave a limit, no number (the forecaster's own chance of this, stated with the estimate: 70%); the middle value sits exactly at the limit.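

In this assay compound 1 reads > 50000 nM, which is a limit. Among the compounds shown here, compound 4 reads > 50000 nM, also a limit, so no step from compound 1 to compound 4 can be read. Such readings recur among the compounds shown: the limit of > 50000 nM in this assay, at which 2 of the 4 values shown sit. As far as these compounds go, what remains open is how cyclopropyl and cyclohexyl would compare on a compound giving readable numbers in this assay.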